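A few compounds are considered here, and "the series" means these few. Any claim that something is new, unique, unknown or untested is made for them only; others in the source may bear on it.

Measured compounds: compound 1 `Cc1ccc(-c2nn(-c3ccc(Cl)cc3)cc2C=O)cc1`, in a functional assay on the whole organism (strain Wistar albino) for inhibition, with Rattus norvegicus as the target, read by paw edema, with stated times of 1 h and 3 h, at a dose of 0.32 mmol/kg by the intraperitoneal route (a lower number here means less inhibition, a higher number more inhibition at the dose given (going by the name of the read-out)), compound 1 gives 56%; compound 2 `COc1ccc(-c2nn(-c3ccc(Cl)cc3)cc2C=O)cc1`, compound 2 gives 57.6%; compound 3 `Cc1ccc(-c2nn(-c3ccc(S(N)(=O)=O)cc3)cc2/C=C\C(=O)c2ccc(Cl)cc2)cc1`, compound 3 gives 47.6%.

Compound 2 differs from compound 1 by a single change, (methoxy in place of methyl on an aromatic carbon). The measured step that goes with it is a number 1.6 percentage points higher from compound 1 to compound 2 (within the scatter), so the two numbers sit together within the usual scatter. Compound 3 carries a different core; the difference between the two cores is not broken down here, and all that the numbers show is that compound 3 and compound 1 are within the scatter of each other.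

Compound 4 `COc1ccc(-c2nn(-c3ccc(S(N)(=O)=O)cc3)cc2/C=C\C(=O)c2ccc(Cl)cc2)cc1` has not yet been measured. It stands to compound 3 exactly as compound 2 stands to compound 1: the change is methoxy in place of methyl on an aromatic carbon, and the place described is the same word for word in both pairs, so this is the same change made on the other core. Going by the values given here, because the only measured example of this change, a number 1.6 percentage points higher from compound 1 to compound 2 (within the scatter), stayed within the scatter, the expected step is likewise small, a number 1.4 percentage points higher from compound 3 to compound 4 (within the scatter), in this assay. On that basis compound 4 is estimated at 49%, with a likely range from 38% to 60%.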

Compound 4, a percentage reported as inhibition, in the whole organism at one dose (the size of the read-out at that dose, not a potency): 56%
Beside the measured number, compound 4's estimate is 7 percentage points below it, within the range that was stated.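

In this assay, the change from 4-methylphenyl to 4-methoxyphenyl on the second core gives a number 8.4 percentage points higher from compound 3 to compound 4 (within the scatter). Set beside the earlier step, the change carries across the two cores without a difference that can be told from the scatter: the same change on two cores in this assay, a number 1.6 percentage points higher (within the scatter) from compound 1 to compound 2 and a number 8.4 percentage points higher (within the scatter) from compound 3 to compound 4, 6.8 percentage points apart, within the scatter of two such steps. Going by these compounds alone, this shows only that both steps stay small enough to be lost in the scatter, so it does not show that methoxy gives more inhibition than methyl on either core, nor that the two cores respond alike or differently, and two pairs read at a single dose cannot settle a trend.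

The compounds shown hold only methyl and methoxy at this place, so what a longer chain such as ethoxy, a halogen such as chlorine, or an amine would do there remains open. From the compounds shown here alone, whether a step beyond the scatter can be reached at this place on either core also remains open.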